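A few compounds are considered here, and "the series" means these few. Any claim that something is new, unique, unknown or untested is made for them only; others in the source may bear on it.

Compound 1 `CCCCCCCNC[C@@H]1OC[C@H](N)[C@@H]1O`: > 128000 nM (a limit)
Compound 2 `CCCCCCCCCNC[C@@H]1OC[C@H](N)[C@H]1O`: > 128000 nM (a limit)
Compound 3 `CCCCCCCCCCCCCCNC[C@@H]1OC[C@H](N)[C@H]1O`: 64300 nM

These results come from a functional assay on B16-F10 cells (Mus musculus) for antiproliferative activity, read by MTT assay, with a stated time of 72 h; a lower number here means a stronger inhibitor, a higher number a weaker inhibitor. Compound 3 is the only one of the three with a number, 64300 nM, while the other two sit at the limit of > 128000 nM in this assay, at which 2 of the 3 values shown sit. Compound 4 `CCCCCCCNC[C@@H]1OC[C@H](N)[C@H]1O` differs from compound 3 by hydrogen in place of heptyl on a saturated chain carbon, seven bonds along the chain from an amine nitrogen, that is, hydrogen in place of heptyl. Going by the values given here, one measured step bears on this: an at least 1.9-fold lower number from compound 2 to compound 3 (0.29 log units; that floor lies within the scatter), with pentyl in place of hydrogen. Going by these compounds, its floor lies within the scatter, so its true size is unknown. The change to compound 4 runs the opposite way, so a higher number is expected. The expected size is a 2.5-fold higher number from compound 3 to compound 4 (0.40 log units; beyond the scatter), probably ending in a limit. Compound 4 is estimated at 160000 nM, with an expected range of 90000 nM to 300000 nM.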

Compound 4, half-maximal inhibitory concentration: > 128000 nM
Compound 4 ended at the assay's limit (the forecaster's own chance of this, stated with the estimate: 85%); the middle value does not contradict the limit.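

In this assay, going by these compounds, hydrogen in place of heptyl gives an at least 1.9-fold higher number from compound 3 to compound 4 (0.29 log units; that floor lies within the scatter); that floor lies within the scatter, so the true size of this step stays unknown. Compound 4 adds one more result that is a limit rather than a number: the limit of > 128000 nM in this assay, at which 3 of the 4 values shown sit. The steps to compound 4 from compound 2 and from compound 1 cannot be read, so no effect of the drawn configuration can be sized: the fact that compounds 1 and 4 differ only in the configuration as drawn.

On these data alone, it remains open whether a chain longer than that of compound 3 would lower the number further. Also open, as far as these compounds go, is what a phenyl ring on the chain would do.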